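The compounds below may be only part of what the source reports. "The series", "measured", "known", "first", "only" and "open" are said of these compounds alone.

Compound 3, `C[C@@H]1CN(C(=O)OC(C)(C)C)CCN1c1ncc(OCC2CCN(S(C)(=O)=O)CC2)cn1`, stands lowest among the three compounds measured in an in vitro functional assay on HEK293S cells for agonist activity at Glucose-dependent insulinotropic receptor (Homo sapiens), read by HTRF and cAMP accumulation, with a stated time of 45 min (on this read-out lower numbers stand for an effect already at smaller amounts and higher numbers for an effect only at larger amounts of compound), where compound 3 gives 29 nM. Its nearest neighbour is compound 2, `C[C@@H]1CN(C(=O)OC(C)(C)C)C[C@H](C)N1c1ncc(OCc2ccc(S(C)(=O)=O)cc2)cn1`, for which the same assay gives 64 nM; that gap lies beyond the usual scatter. Furthest away is compound 1, `CC(C)(C)OC(=O)N1CCN(c2ncc(OCc3ccc(S(C)(=O)=O)cc3)nn2)CC1`, which in this assay gives 161 nM, again a gap beyond the scatter.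

Compound 4, `C[C@@H]1CN(C(=O)OC(C)(C)C)CCN1c1ncc(OCc2ccc(S(C)(=O)=O)cc2F)cn1`, is the unmeasured partner of compound 3. The change is 2-fluoro-4-(methylsulfonyl)phenyl in place of 1-(methylsulfonyl)piperidin-4-yl on a saturated chain carbon bound to an oxygen on an aromatic ring. Going by the values given here, no measured pair shows this particular exchange on its own, so the size of the step can only be guessed from how the other compounds sit. Compound 2 carries an aromatic methylsulfonyl group and in this assay gives 64 nM, a weaker result than compound 3. On that basis compound 4 is expected to land slightly above compound 3, with a step of a 1.6-fold higher number from compound 3 to compound 4 (0.19 log units; within the scatter) that may not exceed the scatter. The estimate for compound 4 in this assay is 45 nM, in the range 15 nM to 140 nM.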

Compound 4, half-maximal effective concentration: 3 nM
For compound 4 the middle estimate is 15-fold (1.18 log units) above the measured one, and the stated range ends above it.
By their numbers in this assay, from the lowest: compound 4; then compound 3; then compound 2; then compound 1.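

Exchanging 1-(methylsulfonyl)piperidin-4-yl for 2-fluoro-4-(methylsulfonyl)phenyl on a saturated chain carbon bound to an oxygen on an aromatic ring gives a 9.7-fold lower number from compound 3 to compound 4 (0.99 log units; beyond the scatter) in this assay and is the only single-place comparison among these compounds. It shows that the read-out at this position depends on the group carried there, and that the six-membered non-aromatic ring can give way to an aromatic ring of carbon only, with a lower number and with the donor and acceptor counts unchanged. Nothing measured here accounts for the size of this step.

The ring and the fluorine enter together, so the compounds shown leave open how much of the step belongs to each. Also open, on these data alone, is how a chlorine or a nitrile in place of that fluorine, or a carboxylic acid in place of the methylsulfonyl group, would read at this position.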